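Pyridin-2-yl amide replacing the vinylphenyl amide

A few compounds are considered here, and "the series" means these few. Any claim that something is new, unique, unknown or untested is made for them only; others in the source may bear on it.

For the measured compounds named here, compound 1 `C=Cc1cccc(C(=O)NCN2CCC(c3cccc[n+]3[O-])CC2)c1` holds the lower of the two numbers so far in a functional assay on HEK293 cells for agonist activity at D(4) dopamine receptor (Homo sapiens), read by FLIPR; a higher number here means that more compound is needed for the effect, a lower number that less compound is needed: compound 1 gives 68 nM, while compound 2 `CCOc1cccc(C(=O)NCN2CCC(c3cccc[n+]3[O-])CC2)c1` gives 324 nM. Going by the values given here, the single measured step, a 4.8-fold higher number from compound 1 to compound 2 (0.68 log units; beyond the scatter), shows that swapping the substituent on the aromatic ring of the amide moves the number by a modest amount. Compound 3 `O=C(NCN1CCC(c2cccc[n+]2[O-])CC1)c1ccccn1` differs from compound 1 by pyridin-2-yl in place of 3-vinylphenyl on a carbonyl carbon. Among the compounds with values here, no measured step covers an exchange of the whole aromatic ring, so only the step from compound 1 to compound 2 bears on it; that step also removes the vinyl, and compound 3 removes it as well. Within the data shown here, a rise of roughly that size in this assay is therefore expected, with wide uncertainty because a 4.8-fold higher number from compound 1 to compound 2 (0.68 log units; beyond the scatter) is the only guide. Compound 3 is expected at 300 nM, between 80 nM and 1200 nM. The expected step is a 4.4-fold higher number from compound 1 to compound 3 (0.64 log units; beyond the scatter).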

Compound 3, half-maximal effective concentration: 3150 nM
Beside the measured number, compound 3's estimate is 11-fold (1.02 log units) below it; measured number above the stated range.
By their numbers in this assay, from the lowest: compound 1; then compound 2; then compound 3.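

Exchanging the whole aromatic group on the carbonyl carbon moves the number much further in this assay than changing the substituent alone: a 46-fold higher number from compound 1 to compound 3 (1.67 log units; beyond the scatter) for pyridin-2-yl in place of 3-vinylphenyl, against a 4.8-fold higher number from compound 1 to compound 2 (0.68 log units; beyond the scatter) for ethoxy in place of vinyl. This position is therefore far more sensitive to replacement of the whole group than the earlier step showed. The step removes the vinyl and brings in a ring nitrogen at once, so the two changes cannot be separated, and no measurement at hand accounts for the size of the step.

Still open, going by these compounds, is whether an unsubstituted phenyl on the carbonyl carbon would fall nearer compound 1 or compound 3. Also open, on these data alone, is whether a pyridine ring carrying a vinyl group would regain the number of compound 1.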